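Swapping bromo for methoxy on the shared core of compound 2

The source may hold more compounds than are shown below. What is called first, only, known or untested is meant among the compounds shown, and "the series" means these compounds.

Three compounds share one core and were tested in a functional assay on SW480 cells (Homo sapiens) for antiproliferative activity, read by MTT assay, with a stated time of 48 h; on this read-out lower numbers stand for stronger inhibition and higher numbers for weaker inhibition. Compound 1 `O=c1cc(-n2cc(CSc3ccccc3)nn2)c2cc(Br)ccc2o1` gives 15400 nM. Compound 2 `O=c1cc(-n2cc(COc3ccc(F)cc3)nn2)c2cc(Br)ccc2o1` gives 1770 nM, the lowest of the three numbers. Compound 3 `COC(=O)c1ccc(OCc2cn(-c3cc(=O)oc4ccc(Br)cc34)nn2)cc1` gives 3620 nM. The two known steps change the side chain hanging from the triazole: an 8.7-fold lower number from compound 1 to compound 2 (0.94 log units; beyond the scatter), and a 2.0-fold higher number from compound 2 to compound 3 (0.31 log units; beyond the scatter). Both lie beyond the scatter and show the read-out responds to changes in that chain.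

Compound 4 `COc1ccc2oc(=O)cc(-n3cc(COc4ccc(F)cc4)nn3)c2c1` differs from compound 2 elsewhere: methoxy in place of bromo on an aromatic carbon. Going by the values given here, no measured step touches this position, so there is no direct guide for direction or size. The step is expected to be modest, and without evidence for a gain the safer expectation is a small rise in the number, a 2.0-fold higher number from compound 2 to compound 4 (0.30 log units; within the scatter), with a range wide enough to admit no change or a loss. Compound 4 is therefore estimated at 3500 nM in this assay, between 900 nM and 14000 nM.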

Compound 4, half-maximal inhibitory concentration: 25900 nM
Compound 4: the middle estimate sits 7.4-fold (0.87 log units) below what was measured; the measured number lies above the stated range.
By their numbers in this assay, from the lowest: compound 2; then compound 3; then compounds 1 and 4 (each within the scatter of the next).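

In this assay, methoxy in place of bromo on an aromatic carbon of the shared core gives a 15-fold higher number from compound 2 to compound 4 (1.17 log units; beyond the scatter) and so weakens inhibition. The earlier compounds shown here showed only that the side chain matters, as in an 8.7-fold lower number from compound 1 to compound 2 (0.94 log units; beyond the scatter), whereas this pair shows that the read-out also responds strongly to a change on the core, and that with this side chain bromo gives the much lower number. Nothing shown here explains why this swap has so large an effect.

From the compounds shown here alone, whether a smaller or different group on this carbon, such as chloro, hydroxyl or an amine, would keep the number near that of compound 2 remains open. Going by these compounds, it is also open whether the same swap would have a similar effect with the side chains of compound 1 and compound 3.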